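Working notes on amide variation across the shared core

The compounds below may be only part of what the source reports. "The series", "measured", "known", "first", "only" and "open" are said of these compounds alone.

Measured so far, in a functional assay on WI-38 VA13 cells (Homo sapiens) for cytotoxicity; a higher number here means that more compound is needed for the effect, a lower number that less compound is needed:
- compound 1, `O=C(Nc1ccc2nc(NC(=O)C3CCCCC3)sc2c1)c1ccccc1F`: 0.14 ug/mL
- compound 2, `Cc1ccc(F)cc1S(=O)(=O)Nc1ccc2nc(NC(=O)C3CCCCC3)sc2c1`: 0.7 ug/mL
- compound 3, `CC(C)CC(=O)Nc1nc2ccc(NC(=O)c3c(Cl)cccc3Cl)cc2s1`: 0.012 ug/mL

Compound 3 has the lowest number of the three. The gap from compound 3 to compound 1 is beyond the scatter, and the gap from compound 3 to compound 2 is wider still, also beyond the scatter. Among the compounds with values here, no pair of measured compounds differs in only one place, so no single change has yet been isolated in this assay.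

Compound 4, `COC(=O)Nc1nc2ccc(NC(=O)c3c(Cl)cccc3Cl)cc2s1`, is the next to be measured. It keeps the dichlorobenzoyl side of compound 3 and changes the other end: methoxy in place of isobutyl on a carbonyl carbon, which reads isobutylcarbonyl to methoxycarbonyl, or (isobutylcarbonyl)amino to (methoxycarbonyl)amino. Within the data shown here, no measured step gives a precedent for this exchange, so the direction rests on judgement alone. The working expectation is a modest rise in the number, estimated as a 3.3-fold higher number from compound 3 to compound 4 (0.52 log units; beyond the scatter), with a real chance of no change beyond the scatter. For compound 4 in this assay the estimate is 0.04 ug/mL, with a range from 0.008 ug/mL to 0.3 ug/mL.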

Compound 4, half-maximal effective concentration: 0.0095 ug/mL
Estimate against measurement, compound 4: 4.2-fold (0.62 log units) above, and the stated range covers the measured number.
By their numbers in this assay, from the lowest: compounds 4 and 3 (each within the scatter of the next); then compound 1; then compound 2.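

In this assay, the exchange of isobutyl for methoxy on a carbonyl carbon gives a 1.3-fold lower number from compound 3 to compound 4 (0.10 log units; within the scatter), the first single change isolated in this series. With the dichlorobenzoyl side held fixed, going from 4 heavy atoms and 0 hydrogen-bond acceptors in the isobutyl group to 2 heavy atoms and 1 hydrogen-bond acceptor in the methoxy group leaves no difference that can be read in this assay, so the two groups cannot be told apart here by their numbers. Nothing measured accounts for this flat step, and no supporting data on it are available.

Whether this flat result extends beyond these two groups remains open, as no value is shown for a longer chain, an amine or a carboxylic acid on the same carbonyl carbon. From the compounds shown here alone, it is also open whether the same exchange would read alike with the other end of compound 1 or compound 2 in place of the dichlorobenzoyl side, since each of those compounds differs from compound 3 and compound 4 in more than one place.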